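Paw edema series: furan-2-yl in place of 4-chlorophenyl

This account rests on a few compounds, and the source may have more. Where it says the series, first, only, none or still open, it means among the compounds named here.

Measured so far:
compound 1 `CN1C[C@@H](c2ccccc2)[C@@]2(Cc3ccccc3C2=O)[C@@]12C(=O)Nc1ccccc12`: 40%
compound 2 `CN1C[C@@H](c2ccc(Cl)cc2)[C@@]2(Cc3ccccc3C2=O)[C@@]12C(=O)Nc1ccccc12`: 28.4%

Within the data shown here, in a functional assay on the whole organism (strain Wister albino) for inhibition, with Rattus norvegicus as the target, read by paw edema, with stated times of 1 h and 2 h, at a dose of 50 mg/kg by the intraperitoneal route (on this read-out higher numbers stand for more inhibition at the one dose given (going by the name of the read-out) and lower numbers for less inhibition), compound 2 stands lowest of the two numbers; its nearest neighbour is compound 1, and the only step, a number 11.6 percentage points lower from compound 1 to compound 2 (beyond the scatter), is modest but beyond the scatter. Compound 3 `CN1C[C@@H](c2ccco2)[C@@]2(Cc3ccccc3C2=O)[C@@]12C(=O)Nc1ccccc12` differs from compound 2 by furan-2-yl in place of 4-chlorophenyl on a saturated ring carbon. Among the measured compounds shown here, no measured step covers a furan-2-yl entering, so only the removal of the chloro is informative, and compound 1 suggests a modest rise. Compound 3 is therefore expected at 35%, range 22% to 48%, an expected step of a number 6.6 percentage points higher from compound 2 to compound 3 (within the scatter).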

Compound 3, a percentage reported as inhibition, in the whole organism at one dose (the size of the read-out at that dose, not a potency): 53.6%
For compound 3 the middle estimate is 18.6 percentage points below the measured one; the measured number lies above the stated range.
By their numbers in this assay, from the lowest: compound 2; then compound 1; then compound 3.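

In this assay the step of a number 25.2 percentage points higher from compound 2 to compound 3 (beyond the scatter) and the step of a number 13.6 percentage points higher from compound 1 to compound 3 (beyond the scatter) both lie beyond the scatter, so this saturated ring carbon is not limited to six-membered carbon rings. Furan-2-yl gives the highest number of the series, which the chloro step alone could not show. Nothing measured here explains the gain.

Still open, as far as these compounds go, is whether the gain belongs to the ring oxygen or to the five-membered ring itself. Thiophen-2-yl, furan-3-yl or pyridin-2-yl at this carbon would separate these readings.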